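The source may report more compounds than this note shows. Statements on the series, on what has been measured and on what is new or still open speak of the compounds shown alone.

Working notes on the ester series built on the shared core of compound 1 `CC1(C)[C@H]2CC[C@]1(C)[C@H](OC(=O)CCCN1CCCCC1)C2`.

Within the data shown here, in an ADME assay on HEK-293T cells (Homo sapiens) for cytotoxicity, read by MTT assay, with a stated time of 48 h (a higher number here means that more compound is tolerated, a lower number that less compound is tolerated), compound 1 gives 74800 nM, the lowest of the three numbers measured so far. Compound 2 `CN1CCN(CCC(=O)O[C@@H]2C[C@@H]3CC[C@@]2(C)C3(C)C)CC1` gives 282000 nM and compound 3 `CCN1CCN(CCC(=O)O[C@@H]2C[C@@H]3CC[C@@]2(C)C3(C)C)CC1` gives 264000 nM in this assay.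

Compound 4 `CCN1CCN(CCCC(=O)O[C@@H]2C[C@@H]3CC[C@@]2(C)C3(C)C)CC1` is not yet measured. It differs from compound 1 by 4-ethylpiperazin-1-yl in place of piperidin-1-yl on a saturated chain carbon, three bonds along the chain from a carbonyl carbon.

Among the measured compounds shown here, two measured steps bear on this change. The exchange of a piperidine-type amine for a piperazine-type amine gave a 3.8-fold higher number from compound 1 to compound 2 (0.58 log units; beyond the scatter). Lengthening the substituent on the second ring nitrogen gave a 1.1-fold lower number from compound 2 to compound 3 (0.03 log units; within the scatter), so that part of the change should contribute nothing beyond the scatter. A step of the size seen between compound 1 and compound 2 is therefore expected, in the direction of a higher number, with no basis for anything larger since the chain length in compound 4 is kept from compound 1.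

Compound 4 is estimated at 250000 nM, with a range from 110000 nM to 550000 nM, which means an expected step of a 3.3-fold higher number from compound 1 to compound 4 (0.52 log units; beyond the scatter).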

Compound 4, half-maximal cytotoxic concentration: 131000 nM
The estimate for compound 4 lay 1.9-fold (0.28 log units) above the measured number; low and high end bracket the measured number.
By their numbers in this assay, from the lowest: compounds 1, 4, 3 and 2 (each within the scatter of the next, the first and the last beyond it).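

In this assay, with the chain kept, 4-ethylpiperazin-1-yl in place of piperidin-1-yl on a saturated chain carbon, three bonds along the chain from a carbonyl carbon, gives a 1.8-fold higher number from compound 1 to compound 4 (0.24 log units; within the scatter). This exchange at this position therefore produces no step beyond the scatter, whereas the earlier change, which also altered where the amine sits on the chain, gave a 3.8-fold higher number from compound 1 to compound 2 (0.58 log units; beyond the scatter). The ring exchange alone thus does not reproduce the earlier step, and no measured evidence bears on the reason for this difference.

The compounds shown leave open how an open-chain amine such as diethylamino would read at this position in this assay. They also leave open whether a longer chain would keep the number within the scatter of compound 1.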